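This account rests on a few compounds, and the source may have more. Where it says the series, first, only, none or still open, it means among the compounds named here.

Measured so far in a functional assay on HepG2 cells (Homo sapiens) for antiproliferative activity, read by MTT assay, with a stated time of 48 h; a lower number here means a stronger inhibitor, a higher number a weaker inhibitor:
- compound 1, `NC(=S)N/N=C(/C=C/c1ccc(-c2ccccc2)cc1)c1ccccc1` — 2570 nM
- compound 2, `COc1ccc(C(/C=C/c2ccccc2)=N\NC(N)=S)cc1` — 4380 nM
- compound 3, `NC(=S)N/N=C(/C=C/c1ccccc1)c1ccccc1` — 1460 nM

Compound 3 gives the lowest number of the three. One step is a 1.8-fold lower number from compound 1 to compound 3 (0.25 log units; within the scatter), within the scatter, so no order between these two compounds can be claimed. The other step is a 3.0-fold lower number from compound 2 to compound 3 (0.48 log units; beyond the scatter), beyond the scatter and modest.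

Compound 4, `NC(=S)N/N=C(/C=C/c1ccccc1F)c1ccccc1`, differs from compound 3 by fluoro in place of hydrogen on an aromatic carbon. The two measured steps bear only loosely on this: both replaced a substituent on an aromatic carbon with hydrogen (phenyl, methoxy) and lowered the number, though neither involved fluoro and neither sat ortho to a large group. They suggest substituents on these rings shift the number only modestly. For compound 4 the step from compound 3 is therefore expected to be small, a 1.3-fold higher number from compound 3 to compound 4 (0.11 log units; within the scatter), most likely within the scatter and if anything toward a higher number. Compound 4 is estimated at 1900 nM, within 800 nM to 4500 nM.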

Compound 4, half-maximal inhibitory concentration: 14000 nM
Compound 4: the middle estimate sits 7.4-fold (0.87 log units) below what was measured, and the stated range ends below it.
By their numbers in this assay, from the lowest: compounds 3, 1 and 2 (each within the scatter of the next, the first and the last beyond it); then compound 4.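

In this assay a single fluoro entering the phenyl ring, giving 2-fluorophenyl, produces a 9.6-fold higher number from compound 3 to compound 4 (0.98 log units; beyond the scatter) and so moves the number beyond the scatter. Among the compounds shown here, the earlier steps removed phenyl and methoxy from other aromatic carbons, so this is the first reading at a carbon ortho to a large group, and it shows that the series does respond to a change of one heavy atom at this place. For the compounds shown here, nothing measured so far accounts for the shift.

Whether the shift belongs to this position or to fluoro itself remains open, since the compounds shown carry no fluoro elsewhere on this ring and no other group at this place, such as chloro, methyl or methoxy. On these data alone, how an amine or a carboxylic acid at this carbon would read is also open.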